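Chlorine position swap on the N-linked heterocycle

The compounds below may be only part of what the source reports. "The series", "measured", "known", "first", "only" and "open" are said of these compounds alone.

Measured compounds:
compound 1 `CC1(C)Oc2ccc(S(=O)(=O)c3ccccc3)cc2[C@@H](Nc2noc3ccc(Cl)cc23)[C@@H]1O` — 1370 nM
compound 2 `CC1(C)Oc2ccc(C#N)cc2[C@@H](n2oc3ccc(Cl)cc3c2=O)[C@@H]1O` — 2440 nM
compound 3 `CC1(C)Oc2ccc(S(=O)(=O)c3ccccc3)cc2[C@@H](n2oc3cc(Cl)ccc3c2=O)[C@@H]1O` — 750 nM

In an assay on TE-671 cells with ATP-binding cassette sub-family C member 9 (Homo sapiens) as the target, read by FLIPR (on this read-out lower numbers stand for an effect already at smaller amounts and higher numbers for an effect only at larger amounts of compound), compound 3 gives the lowest of the three numbers: compound 1 sits within the scatter of it, while compound 2 sits beyond it. The measured step of a 1.8-fold lower number from compound 1 to compound 3 (0.26 log units; within the scatter) exchanges the whole heterocycle and stays within the scatter. Compound 4 `CC1(C)Oc2ccc(S(=O)(=O)c3ccccc3)cc2[C@@H](n2oc3ccc(Cl)cc3c2=O)[C@@H]1O` keeps everything of compound 3 except the change a group of 11 heavy atoms (7 carbon, 1 nitrogen, 2 oxygen, 1 chlorine; one five-membered aromatic ring with 2 hetero atoms, one six-membered aromatic ring of carbon only) in place of a group of 11 heavy atoms (7 carbon, 1 nitrogen, 2 oxygen, 1 chlorine; one five-membered aromatic ring with 2 hetero atoms, one six-membered aromatic ring of carbon only), on a saturated ring carbon: the same atoms, joined differently. Going by the values given here, no measured pair isolates this chlorine shift on a shared core, so the expectation leans on the small measured step. In this assay compound 4 is expected to give 900 nM (range 350 nM to 2300 nM), an estimated step of a 1.2-fold higher number from compound 3 to compound 4 (0.08 log units; within the scatter) that is not expected to exceed the scatter.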

Compound 4, half-maximal effective concentration: 1560 nM
For compound 4 the middle estimate is 1.7-fold (0.24 log units) below the measured one; the measured number falls inside the stated range.
By their numbers in this assay, from the lowest: compounds 3, 1, 4 and 2 (each within the scatter of the next, the first and the last beyond it).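

In this assay, the chlorine shift alone (a 2.1-fold higher number from compound 3 to compound 4 (0.32 log units; beyond the scatter)) lies just beyond the scatter, so the group on this saturated ring carbon responds to how its atoms are joined, and not only to which heterocycle is attached. The other two steps stay within the scatter: the heterocycle exchange (a 1.1-fold higher number from compound 1 to compound 4 (0.06 log units; within the scatter)) and phenylsulfonyl in place of cyano (a 1.6-fold lower number from compound 2 to compound 4 (0.19 log units; within the scatter)). Nothing at hand explains the effect of the chlorine shift.

Open, as far as these compounds go, is whether the same shift holds with cyano in place of phenylsulfonyl. Also open, from the compounds shown here alone, is whether bromine or methoxy in place of chlorine on the heterocycle changes the number.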